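Swapping phenoxy for ((4-bromophenyl)sulfonyl)amino in compound 3

This account rests on a few compounds, and the source may have more. Where it says the series, first, only, none or still open, it means among the compounds named here.

For the measured compounds named here, in a functional assay on MGC-803 cells (Homo sapiens) for antiproliferative activity, read by MTT assay, with a stated time of 48 h (a lower number here means a stronger inhibitor, a higher number a weaker inhibitor), compound 2 (`COc1ccc(CN(C(=O)Cn2cc(COc3ccccc3)nn2)c2cc(OC)c(OC)c(OC)c2)cc1`) gives 12500 nM, the higher of the two numbers measured so far. Compound 1 (`COc1ccc(CN(C(=O)Cn2cc(COc3ccc4ccc(=O)oc4c3)nn2)c2cc(OC)c(OC)c(OC)c2)cc1`) gives 180 nM. Compound 3 (`COc1ccc(CN(C(=O)Cn2cc(CNS(=O)(=O)c3ccc(Br)cc3)nn2)c2cc(OC)c(OC)c(OC)c2)cc1`) keeps the shared core of compound 2 and differs from it as follows: ((4-bromophenyl)sulfonyl)amino in place of phenoxy on a saturated chain carbon bound to an aromatic carbon. Going by the values given here, only one measured step bears on this change, a 69-fold higher number from compound 1 to compound 2 (1.84 log units; beyond the scatter), a large step that also alters the group held on that oxygen. That step shows that changes in this part of the molecule can move the number far, but it involves no ((4-bromophenyl)sulfonyl)amino group, so it speaks to size more than direction. A moderate move toward a lower number is expected, well short of that large step, and the expected step is a 3.1-fold lower number from compound 2 to compound 3 (0.49 log units; beyond the scatter). For compound 3 the estimated value is 4000 nM, with an expected range from 600 nM to 20000 nM.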

Compound 3, half-maximal inhibitory concentration: 430 nM
The estimate for compound 3 lay 9.3-fold (0.97 log units) above the measured number, and the stated range ends above it.
By their numbers in this assay, from the lowest: compound 1; then compound 3; then compound 2.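

In this assay, putting ((4-bromophenyl)sulfonyl)amino in place of phenoxy gives a 29-fold lower number from compound 2 to compound 3 (1.46 log units; beyond the scatter), so a large fall in the number at this saturated chain carbon does not depend on the two-ring group carried by compound 1. Compound 3 does not fully match that group, however, as the comparison shows a 2.4-fold higher number from compound 1 to compound 3 (0.38 log units; beyond the scatter), a modest step that is still beyond the scatter. No measurement shown here explains either step.

The compounds shown leave open whether the gain over phenoxy belongs to the sulfonyl amino link, to the bromine or to both together. A plain phenylsulfonylamino group would test the bromine, and a benzoylamino group would test the sulfonyl link.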